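A few compounds are considered here, and "the series" means these few. Any claim that something is new, unique, unknown or untested is made for them only; others in the source may bear on it.

Compound 2 `COc1cc(-c2cc(/C=C/C(=O)c3ccc(N)cc3)[nH]n2)cc(OC)c1OC` sits among three closely grouped numbers in a functional assay on M14 cells (Homo sapiens) for inhibition, read by sulforhodamine B assay, with a stated time of 48 h; on this read-out lower numbers stand for stronger inhibition of growth and higher numbers for weaker inhibition of growth. Compound 2 gives 3860 nM, compound 3 `COc1ccc(C(=O)/C=C/c2cc(-c3cc(OC)c(OC)c(OC)c3)n[nH]2)cc1OC` gives 3690 nM, and compound 1 `COc1ccc(-c2cc(/C=C/C(=O)c3ccc(N)cc3)[nH]n2)cc1` gives 6540 nM; all three lie within the scatter of one another. Going by the values given here, the only single-place step measured so far, a 1.0-fold lower number from compound 2 to compound 3 (0.02 log units; within the scatter), concerns the aryl group on the carbonyl carbon, not the ring changed here. Compound 4 `COc1ccc(-c2cc(/C=C/C(=O)c3ccc(N)cc3)[nH]n2)cc1OC` differs from compound 2 by hydrogen in place of methoxy on an aromatic carbon, which moves the structure toward compound 1, whose number stands within the scatter of that of compound 2. Among the compounds with values here, with no step bearing directly on this change, only a small shift is expected in this assay, so a 1.3-fold higher number from compound 2 to compound 4 (0.11 log units; within the scatter) is the estimated step, and compound 4 is expected to give about 5000 nM, within a range from 2000 nM to 12000 nM.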

Compound 4, concentration for total growth inhibition: 5110 nM
Beside the measured number, compound 4's estimate is 1.0-fold (0.01 log units) below it; the range from low to high includes it.
By their numbers in this assay, from the lowest: compounds 3, 2, 4 and 1 (each within the scatter of the next).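

In this assay, hydrogen in place of methoxy on this aromatic carbon gives a 1.3-fold higher number from compound 2 to compound 4 (0.12 log units; within the scatter) and the reverse change, methoxy in place of hydrogen on an aromatic carbon, gives a 1.3-fold lower number from compound 1 to compound 4 (0.11 log units; within the scatter) on the same ring. Both single changes to this ring therefore stay within the usual scatter. Nothing available explains this result. Open, from the compounds shown here alone, is whether a hydroxyl group or a chlorine atom on this aromatic carbon would also stay within the scatter. Also open, going by these compounds, is whether hydrogen in place of methoxy behaves alike with 3,4-dimethoxyphenyl on the carbonyl carbon.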